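The source may report more compounds than this note shows. Statements on the series, on what has been measured and on what is new or still open speak of the compounds shown alone.

Measured compounds: compound 1 `NNc1nc2ccc(Br)cc2s1` at 8.01 ug/mL; compound 2 `Cc1ccc2nc(NN)sc2c1` at 4.52 ug/mL; compound 3 `Clc1ccc(-c2nnc(-c3cccnc3)n2Nc2nc3ccc(Br)cc3s2)cc1` at 29.6 ug/mL.

In an ADME assay on MT4 cells (Homo sapiens) for cytotoxicity, read by MTT assay, with a stated time of 5 days (on this read-out lower numbers stand for higher toxicity in this test and higher numbers for lower toxicity in this test), compound 1 gives 8.01 ug/mL and compound 2 gives 4.52 ug/mL. Compound 2 differs from compound 1 by methyl in place of bromo on an aromatic carbon, a step of a 1.8-fold lower number from compound 1 to compound 2 (0.25 log units; within the scatter). Compound 3 gives 29.6 ug/mL; it and compound 1 differ in more than one place, and the difference between the two cores is not broken down here. Compound 4 `Cc1ccc2nc(Nn3c(-c4ccc(Cl)cc4)nnc3-c3cccnc3)sc2c1` has not yet been measured. It stands to compound 3 as compound 2 stands to compound 1, through (methyl in place of bromo on an aromatic carbon), the same change at the same place, which occurs twice among the compounds shown. Compound 4 is expected to give 20 ug/mL, a step of a 1.5-fold lower number from compound 3 to compound 4 (0.17 log units; within the scatter), resting on a 1.8-fold lower number from compound 1 to compound 2 (0.25 log units; within the scatter). The value of compound 4 is estimated to fall between 8 ug/mL and 45 ug/mL.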

Compound 4, half-maximal cytotoxic concentration: 75.5 ug/mL
Compound 4: the middle estimate sits 3.8-fold (0.58 log units) below what was measured, outside the stated range (above it).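

In this assay, methyl in place of bromo on an aromatic carbon brings a 2.6-fold higher number from compound 3 to compound 4 (0.41 log units; beyond the scatter), and the same change does not give the same result on the two cores: the same change on two cores in this assay, a 1.8-fold lower number (0.25 log units; within the scatter) from compound 1 to compound 2 and a 2.6-fold higher number (0.41 log units; beyond the scatter) from compound 3 to compound 4, 4.5-fold (0.66 log units) apart, beyond the scatter of two such steps. In this series, then, the step seen on one core cannot be taken as a guide to the step on the other. The two pairs do not show why the cores part, and they set no rule for any further core.

From the compounds shown here alone, it remains open how an amine or a carboxylic acid at that aromatic carbon would read on either core. Also open, going by these compounds, is whether methyl in place of bromo would follow either step on a third core.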